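The source may report more compounds than this note shows. Statements on the series, on what has been measured and on what is new or still open speak of the compounds shown alone.

Within an assay on isolated protein for inhibition of Dihydrofolate reductase (Homo sapiens), read by spectrophotometry, using NADPH, with a stated time of 10 min (a lower number here means a stronger inhibitor, a higher number a weaker inhibitor), the three measured compounds spread widely. Compound 1 `CC(=O)c1cccc(-c2ccc3c(N)nc(N)nc3c2)c1` gives 323 nM, the highest number of the three. Compound 2 `Cc1ccccc1-c1cc2nc(N)nc(N)c2cc1C` gives 95.6 nM, a lower number and beyond the scatter from compound 1, while compound 3 `CCOc1ccc(-c2cccnc2)cc1-c1ccc2c(N)nc(N)nc2c1` gives 10.1 nM, the lowest of the set and furthest from compound 1. Going by the values given here, none of these pairs differs in a single place, so no isolated step is available from them. Compound 4 `Nc1nc(N)c2ccc(-c3ccccc3)cc2n1` is related to compound 1 by hydrogen in place of acetyl on an aromatic carbon, meta to a large group. Lacking a measured step of this kind, the expectation is a modest shift toward a lower number, near the scatter, as the step of a 1.6-fold lower number from compound 1 to compound 4 (0.21 log units; within the scatter). Compound 4 is therefore estimated at 200 nM, within 60 nM to 700 nM.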

Compound 4, inhibition constant: 743 nM
The estimate for compound 4 lay 3.7-fold (0.57 log units) below the measured number; measured number outside the range, above it.
By their numbers in this assay, from the lowest: compound 3; then compound 2; then compound 1; then compound 4.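

In this assay the series now has its first step in one place: hydrogen in place of acetyl on the aromatic carbon, meta to a large group, gives a 2.3-fold higher number from compound 1 to compound 4 (0.36 log units; beyond the scatter) on the shared core. At this position, then, the acetyl goes with the lower number, by a modest margin beyond the scatter. Nothing measured here accounts for the direction of this step.

On these data alone, whether the carbonyl or the whole acetyl carries this step stays open. So does how an amine, a carboxylic acid or a methoxy group on the same carbon would compare with the acetyl.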